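The compounds below may be only part of what the source reports. "The series", "measured", "known", "first", "only" and "open" are said of these compounds alone.

Compound 1 `C=C1C(=O)O[C@H]2CC3=C[C@H](C/C(C)=C/[C@@H](OC(=O)c4ccc([N+](=O)[O-])cc4)[C@H]12)OC3=O` and compound 2 `C=C1C(=O)O[C@H]2CC3=C[C@H](C/C(C)=C/[C@@H](OC(=O)CCCCC)[C@H]12)OC3=O` share one core and differ only in the group on a carbonyl carbon. In a functional assay on A549 cells (Homo sapiens) for cytotoxicity, read by MTT assay, with a stated time of 48 h (on this read-out lower numbers stand for stronger inhibition and higher numbers for weaker inhibition), compound 1 gives > 10000 nM, which is a limit and not a number. In this assay compound 2 gives > 10000 nM, again a limit, so compound 2 has no number of its own. The whole record so far is the limit of > 10000 nM in this assay, at which 2 of the 2 values shown sit. Within the data shown here, the one measured step, a step that the two limits leave unreadable from compound 1 to compound 2, therefore has no readable size and offers no measure of how much this group matters.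

Compound 3 `C=C1C(=O)O[C@H]2CC3=C[C@H](C/C(C)=C/[C@@H](OC(=O)C(C)(C)CC)[C@H]12)OC3=O` has the same atoms as compound 2, joined differently: 1,1-dimethylpropyl in place of pentyl on a carbonyl carbon. It carries 1,1-dimethylpropyl in place of pentyl on a carbonyl carbon. Among the measured compounds shown here, with no sized step to draw on, the expectation of no change beyond the scatter rests on compound 2, whose limit is > 10000 nM. The step expected is a step that the limit leaves unreadable from compound 2 to compound 3, an estimate without a firm direction. In this assay the estimate for compound 3 is 12000 nM, expected to fall between 4000 nM and 40000 nM.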

Compound 3, half-maximal inhibitory concentration: 2200 nM
Compound 3: middle estimate off by 5.5-fold (0.74 log units), on the high side; measured number below the stated range.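

In this assay, among these compounds, putting 1,1-dimethylpropyl in place of pentyl on the carbonyl carbon gives an at least 4.5-fold lower number from compound 2 to compound 3 (0.65 log units; beyond the scatter), the first step at this position with a readable size, even if only a lower bound. The two chains hold the same atoms, so how those atoms are joined is enough here to move the read-out beyond the scatter, and the same group in place of 4-nitrophenyl gives an at least 4.5-fold lower number from compound 1 to compound 3 (0.65 log units; beyond the scatter). The step between the other two compounds remains unreadable, and compound 3 is the only one of the three with a number of its own, so both readable steps are bounded on one side only: the limit of > 10000 nM in this assay, at which 2 of the 3 values shown sit.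

Going by these compounds, it remains open whether the lower number belongs to branched chains in general or to 1,1-dimethylpropyl alone, a question that a tert-butyl or isopropyl group on the same carbonyl carbon would address. Also open, on these data alone, are the true sizes of both steps, and whether a chain carrying an amine or a carboxylic acid at this position would keep a measurable number.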